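Small Thiophene Replacing Methoxyphenyl on the Urea

The source may report more compounds than this note shows. Statements on the series, on what has been measured and on what is new or still open speak of the compounds shown alone.

Compound 1, `O=C(Nc1ccc(Nc2ncnc3c2OCCN3)cc1)Nc1ccc(Cl)c(C(F)(F)F)c1`, gives 177 nM in an assay on isolated protein for inhibition of proto-oncogene tyrosine-protein kinase receptor Ret (Homo sapiens), read by 33P incorporation, with stated times of 15 min and 40 min; on this read-out higher numbers stand for weaker inhibition and lower numbers for stronger inhibition.
Compound 2, `COc1cccc(NC(=O)Nc2ccc(Nc3ncnc4c3OCCN4)cc2)c1`, gives 6810 nM in this assay.
Compound 3, `O=C(Nc1ccc(Nc2ncnc3c2OCCN3)cc1)Nc1cccc(-c2ccccc2)c1`, gives only a limit of the assay in this assay: > 10000 nM.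

Compound 2 stands highest of the two numbers recorded; compound 1 sits far lower, beyond the scatter. The structure to be considered next is compound 4, `O=C(Nc1ccc(Nc2ncnc3c2OCCN3)cc1)Nc1cccs1`, which differs from compound 2 by thiophen-2-yl in place of 3-methoxyphenyl on an amide-type nitrogen.

Within the data shown here, only one measured step touches the same amide-type nitrogen: an at least 1.4-fold higher number from compound 2 to compound 3 (0.16 log units; that floor lies within the scatter), where the new value is just the limit described by the limit of > 10000 nM in this assay, at which 1 of the 3 values shown sits. It shows a larger aromatic group at that position giving no gain, but its floor stays within the scatter, so it says little about size of effect. Among the measured compounds shown here, compound 1 shows that a different substituted phenyl at that position reaches a much lower number, yet no single step links it to the thiophene change.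

With so little to lean on, compound 4 is expected to stay close to compound 2. That estimate means a step of a 1.1-fold lower number from compound 2 to compound 4 (0.05 log units; within the scatter), expected to lie within the scatter. Compound 4 is therefore estimated at 6000 nM, between 1500 nM and 20000 nM.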

Compound 4, half-maximal inhibitory concentration: > 10000 nM
Compound 4 was reported as a limit; the forecaster's own chance of this, stated with the estimate: 30%; at least 1.6-fold (0.22 log units) between middle value and limit.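

With thiophen-2-yl in place of 3-methoxyphenyl on the amide-type nitrogen, the step in this assay is an at least 1.4-fold higher number from compound 2 to compound 4 (0.16 log units; that floor lies within the scatter), so swapping the six-membered ring for a smaller five-membered one with a sulfur atom brings no gain in inhibition. Compound 3 had only shown that adding a phenyl group to the ring on this nitrogen brings no gain, whereas this change replaces the ring itself and again brings none, so neither a larger nor a smaller aromatic group here moves the number down from that of compound 2. Compound 4 is reported only as a limit, so the real size of this step cannot be read, and compound 4 now sits with compound 3 at the same ceiling: the limit of > 10000 nM in this assay, at which 2 of the 4 values shown sit.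

Still open is which part of the chloro and trifluoromethyl pattern on the phenyl ring of compound 1 accounts for its much lower number of 177 nM, since no single step links that compound to the others. Also open, on these data alone, is how a thiophene carrying a chlorine atom, or a phenyl ring carrying an amine or a carboxylic acid, would read at this nitrogen.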